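Shrinking the ester group from cyclohexyl to cyclopropylmethyl

A few compounds are considered here, and "the series" means these few. Any claim that something is new, unique, unknown or untested is made for them only; others in the source may bear on it.

Three esters of a shared core have been measured in an assay on membranes from CHO cells for displacement of a labelled ligand from adenosine receptor A1 (Homo sapiens), read by scintillation counting, with a stated time of 60 min, tested at 1 uM; a higher number here means more inhibition at the concentration tested (going by the name of the read-out), a lower number less inhibition. Compound 1 `CCCOC(=O)C1=C(C)NC(=O)NC1c1ccoc1` gives 50%. Compound 2 `CC1=C(C(=O)OC(C)(C)C)C(c2ccoc2)NC(=O)N1` gives 11%, and compound 3 `CC1=C(C(=O)OC2CCCCC2)C(c2ccoc2)NC(=O)N1` gives 15%. On these numbers compound 3 stands second highest of the three: its nearest neighbour is compound 2, separated by a step within the scatter, while compound 1 lies far above it, beyond the scatter.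

The next compound, compound 4 `CC1=C(C(=O)OCC2CC2)C(c2ccoc2)NC(=O)N1`, differs from compound 3 in one place: cyclopropylmethyl in place of cyclohexyl on an oxygen next to a carbonyl group. Going by the values given here, two measured steps bear on this change. Both replacements of propyl at that oxygen lowered the signal heavily, a number 39 percentage points lower from compound 1 to compound 2 (beyond the scatter) and a number 35 percentage points lower from compound 1 to compound 3 (beyond the scatter), whereas a number 4 percentage points higher from compound 2 to compound 3 (within the scatter) shows that tert-butyl and cyclohexyl give the same result within the scatter. Cyclopropylmethyl carries fewer heavy atoms than cyclohexyl, and the only high number among the three comes from the smallest ester, compound 1 with 50%, so a partial recovery is expected, but no measured step supports a full return to that level. The expected step is a number 15 percentage points higher from compound 3 to compound 4 (beyond the scatter), a modest rise that may not clear the scatter. Compound 4 is therefore estimated at 30%, with a range from 10% to 55%.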

Compound 4, a percentage reported as inhibition, at one concentration (the size of the read-out at that concentration, not a potency): 29%
The estimate for compound 4 lay 1 percentage points above the measured number; low and high end bracket the measured number.
By their numbers in this assay, from the lowest: compounds 2 and 3 (each within the scatter of the next); then compound 4; then compound 1.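

In this assay, going by these compounds alone, the earlier compounds gave one high number and two low numbers that could not be told apart, whereas cyclopropylmethyl on this oxygen gives an intermediate level: the change from cyclohexyl, with 6 heavy atoms, to cyclopropylmethyl, with 4 heavy atoms, is a number 14 percentage points higher from compound 3 to compound 4 (beyond the scatter) and the change from tert-butyl is a number 18 percentage points higher from compound 2 to compound 4 (beyond the scatter) in the same direction. The recovery remains partial, for the comparison with the propyl ester is a number 21 percentage points lower from compound 1 to compound 4 (beyond the scatter) and so separates two small esters, showing that this position responds to more than the replacement of a large group alone. The compounds shown offer no measured explanation for these differences.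

What the four esters leave open is whether the trend continues to a methyl or ethyl ester, or whether a longer chain such as butyl would lie above or below the propyl ester of compound 1. They also leave open how a benzyl ester or an amide in place of the ester would read at this position, and, with a single tested concentration, how these percentages translate into potency.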